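From Methyl to Bromo on the Benzyl Group

This account rests on a few compounds, and the source may have more. Where it says the series, first, only, none or still open, it means among the compounds named here.

Compound 1 `Sc1nnc(-c2ccc3c(c2)OCCO3)n1-c1ccccc1`: 38400 nM
Compound 2 `Clc1cccc(CSc2nnc(-c3ccc4c(c3)OCCO4)n2-c2ccccc2)c1`: 10600 nM
Compound 3 `Cc1ccccc1CSc1nnc(-c2ccc3c(c2)OCCO3)n1-c1ccccc1`: 12700 nM

All three compounds were tested in a functional assay on SW 1116 cells (Homo sapiens) for antiproliferative activity, read by MTT assay, with a stated time of 24 h; on this read-out lower numbers stand for stronger inhibition and higher numbers for weaker inhibition. Compound 1 carries a hydrogen on its sulfur. Replacing that hydrogen with a substituted benzyl group gave modest steps: a 3.6-fold lower number from compound 1 to compound 2 (0.56 log units; beyond the scatter), and a 3.0-fold lower number from compound 1 to compound 3 (0.48 log units; beyond the scatter). Compound 3 therefore stands with compound 2 at the low end of the three numbers, clearly apart from compound 1.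

Compound 4 `Brc1ccccc1CSc1nnc(-c2ccc3c(c2)OCCO3)n1-c1ccccc1` keeps the structure of compound 3 except for one change: bromo in place of methyl on an aromatic carbon. This puts bromo in place of methyl on an aromatic carbon, ortho to a large group, turning 2-methylbenzyl into 2-bromobenzyl. Within the data shown here, no bromo compound has been measured yet. The closest guide is a 1.2-fold higher number from compound 2 to compound 3 (0.08 log units; within the scatter), where one benzyl substituent replaced another. The larger steps concern the hydrogen on sulfur, so they bear less on this swap. No step beyond the scatter is therefore expected in this assay. The expected step is a 1.1-fold lower number from compound 3 to compound 4 (0.04 log units; within the scatter). Compound 4 is expected to give about 11500 nM, with an estimated range of 6000 nM to 22000 nM.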

Compound 4, half-maximal inhibitory concentration: 7350 nM
Estimate against measurement, compound 4: 1.6-fold (0.19 log units) above; measured number inside the range.
By their numbers in this assay, from the lowest: compounds 4, 2 and 3 (each within the scatter of the next); then compound 1.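

In this assay bromo can stand in place of methyl on this aromatic carbon, ortho to a large group, with no step beyond the usual scatter (a 1.7-fold lower number from compound 3 to compound 4 (0.24 log units; within the scatter)), and replacing the 3-chlorobenzyl group of compound 2 with 2-bromobenzyl also stays inside that scatter (a 1.4-fold lower number from compound 2 to compound 4 (0.16 log units; within the scatter)). Measured against the hydrogen on sulfur, 2-bromobenzyl gives a step beyond the scatter (a 5.2-fold lower number from compound 1 to compound 4 (0.72 log units; beyond the scatter)), so all three benzyl groups shown now stand apart from compound 1. Nothing measured here explains these numbers.

Going by these compounds, whether this aromatic carbon accepts a very different group, such as an amine or a carboxylic acid, remains open. So does the effect of a longer chain in place of the benzyl group on sulfur, and of bromo elsewhere on the ring.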